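Sulfur-linked aryl variation on the shared core

A few compounds are considered here, and "the series" means these few. Any claim that something is new, unique, unknown or untested is made for them only; others in the source may bear on it.

Measured compounds:
Compound 1, `CCOC(=O)c1c(CSc2cccc(Cl)c2)n(C)c2ccc(O)cc12`, in an assay on cells for inhibition of Polyunsaturated fatty acid 5-lipoxygenase (Homo sapiens), read by HPLC, with a stated time of 15 min (on this read-out lower numbers stand for stronger inhibition and higher numbers for weaker inhibition), gives a limit, > 10000 nM.
Compound 2, `CCOC(=O)c1c(CSc2c(C)cccc2C)n(C)c2ccc(O)cc12`, gives 1200 nM.
Compound 3, `CCOC(=O)c1c(CSc2cc(C)cc(C)c2)n(C)c2ccc(O)cc12`, gives 2700 nM.

Compound 3 holds the higher of the two numbers shown; its nearest neighbour is compound 2, and a 2.3-fold higher number from compound 2 to compound 3 (0.35 log units; beyond the scatter). The result for compound 1 is a limit of the assay, not a number (the limit of > 10000 nM in this assay, at which 1 of the 3 values shown sits). The steps of an at least 8.3-fold lower number from compound 1 to compound 2 (0.92 log units; beyond the scatter) and an at least 3.7-fold lower number from compound 1 to compound 3 (0.56 log units; beyond the scatter) are accordingly known only as bounds.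

Compound 4, `CCOC(=O)c1c(CSc2c(C)cc(C)cc2C)n(C)c2ccc(O)cc12`, differs from compound 3 in one place: 2,4,6-trimethylphenyl in place of 3,5-dimethylphenyl on a sulfur. The change is on a sulfur whose other neighbour is a saturated chain carbon. The step that bears on it most directly is a 2.3-fold higher number from compound 2 to compound 3 (0.35 log units; beyond the scatter), where the 2,6-dimethylphenyl of compound 2 gave the lower number and the 3,5-dimethylphenyl of compound 3 the higher. The 2,4,6-trimethylphenyl entering in compound 4 carries the two methyl groups of the 2,6-dimethylphenyl plus one more, so a modest lowering from compound 3, roughly the reverse of the measured step, is expected, with the added methyl group of unknown effect.

For compound 4 the expected value in this assay is estimated at 1200 nM, with a range from 400 nM to 4000 nM. This expectation corresponds to an estimated 2.3-fold lower number from compound 3 to compound 4 (0.35 log units; beyond the scatter).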

Compound 4, half-maximal inhibitory concentration: 230 nM
The estimate for compound 4 lay 5.2-fold (0.72 log units) above the measured number, and the stated range ends above it.
By their numbers in this assay, from the lowest: compound 4; then compound 2; then compound 3. At a limit, above all of these: compound 1.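

The added methyl group carries more weight than the dimethylphenyl compounds could show: methyl in place of hydrogen on an aromatic carbon gives a 5.2-fold lower number from compound 2 to compound 4 (0.72 log units; beyond the scatter) in this assay and is thus a clear gain on top of the 2,6-dimethylphenyl group. On a sulfur whose other neighbour is a saturated chain carbon, 2,4,6-trimethylphenyl in place of 3,5-dimethylphenyl gives a 12-fold lower number from compound 3 to compound 4 (1.07 log units; beyond the scatter), the largest of the steps between measured numbers in this series. The step of an at least 43-fold lower number from compound 1 to compound 4 (1.63 log units; beyond the scatter) is known only as a bound, the result for compound 1 being a limit and not a number: the limit of > 10000 nM in this assay, at which 1 of the 4 values shown sits.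

Nothing shown accounts for the gain from the added methyl group. As far as these compounds go, it also remains open whether that gain is specific to methyl, which a methoxy group or a chlorine in its place would test, and whether it persists with a carboxylic acid in place of the ethyl ester on the shared core.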